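The source may hold more compounds than are shown below. What is called first, only, known or untested is meant among the compounds shown, and "the series" means these compounds.

Measured so far:
compound 1, `C=C1C(=O)OC[C@@H]1CCOC(=O)Nc1cc(C)cc(C)c1`: 1240 nM
compound 2, `C=C1C(=O)OC[C@@H]1CCOC(=O)Nc1ccc(C(C)C)cc1`: 1580 nM
compound 3, `C=C1C(=O)OC[C@H]1CCOC(=O)Nc1ccc(C(C)C)cc1`: 340 nM

In a functional assay on RAW264.7 cells (Mus musculus) for inhibition, with a stated time of 30 min (a lower number here means a stronger inhibitor, a higher number a weaker inhibitor), compound 2 has the highest of the three numbers; compound 1 sits within the scatter of it, while compound 3 gives the lowest number. Going by the values given here, the only measured single step is a 4.6-fold lower number from compound 2 to compound 3 (0.67 log units; beyond the scatter), and it rests on the fact that compounds 2 and 3 differ only in the configuration as drawn alone. Compound 4, `C=C1C(=O)OC[C@@H]1CCOC(=O)Nc1ccc(C(=O)OCCCC)cc1`, keeps the configuration of compound 2 and changes the aromatic ring instead: butoxycarbonyl in place of isopropyl on an aromatic carbon. Among the compounds with values here, no measured step alters a group on that ring; compounds 1 and 2 carry two different ring substitutions and give numbers within the scatter of each other. A step of a 1.1-fold lower number from compound 2 to compound 4 (0.02 log units; within the scatter) is therefore expected, meaning no change beyond the scatter. Compound 4 is estimated at 1500 nM, with a range from 500 nM to 4500 nM.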

Compound 4, half-maximal inhibitory concentration: 860 nM
For compound 4 the middle estimate is 1.7-fold (0.24 log units) above the measured one; low and high end bracket the measured number.
By their numbers in this assay, from the lowest: compound 3; then compounds 4, 1 and 2 (each within the scatter of the next).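

In this assay the exchange of isopropyl for butoxycarbonyl gives a 1.8-fold lower number from compound 2 to compound 4 (0.26 log units; within the scatter) and so no change that can be told from the scatter. This position on the aromatic ring, para to a large group, therefore accepts a longer group with more heavy atoms and with hydrogen-bond acceptors. The data shown offer no explanation for this result. On these data alone, whether an amine or a carboxylic acid would be accepted here remains open. So does whether butoxycarbonyl would behave the same way in the configuration of compound 3.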